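Methyl for chloro on the core: a sulfonamide series

The source may report more compounds than this note shows. Statements on the series, on what has been measured and on what is new or still open speak of the compounds shown alone.

Measured so far:
- compound 1, `CN1CCc2cc(Cl)c(NS(=O)(=O)c3ccc(-c4ccc(Cl)cc4)cc3)cc2CC1`, 50.1 nM
- compound 2, `Cc1cc(S(=O)(=O)Nc2ccc3c(c2)CCN(C)CC3)ccc1-c1ccc(Cl)cc1`, 5.01 nM
- compound 3, `Cc1noc(C)c1-c1ccc(S(=O)(=O)Nc2ccc3c(c2)CCN(C)CC3)cc1`, 10 nM

Three compounds share a core and a sulfonamide linker, and all three were tested in an assay on isolated protein for displacement of a labelled ligand from 5-hydroxytryptamine receptor 6 (Homo sapiens), read by radioligand binding; a higher number here means a weaker inhibitor, a lower number a stronger inhibitor. Compound 1 gives 50.1 nM, the highest of the three numbers; compound 3 at 10 nM sits lower by a gap beyond the scatter, and compound 2 at 5.01 nM sits lower still, so compound 1 is the weakest of the measured set in this assay. Compound 1 carries a chloro group on its core; in compound 2 the core is bare and a methyl sits on the sulfonyl aryl ring instead.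

The new compound 4, `Cc1cc2c(cc1NS(=O)(=O)c1ccc(-c3ccc(Cl)cc3)cc1)CCN(C)CC2`, keeps everything from compound 1 except one exchange: methyl in place of chloro on an aromatic carbon. Among the compounds with values here, no measured pair isolates this exchange, so its effect has to be guessed. Since the measured compounds with a bare or differently decorated core all gave lower numbers than compound 1, a small downward step in this assay seems more likely than an upward one, though a step within the scatter is also plausible. Compound 4 is therefore expected to give about 30 nM, within 10 nM to 90 nM. The implied step a 1.7-fold lower number from compound 1 to compound 4 (0.22 log units; within the scatter) is expected to be modest.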

Compound 4, inhibition constant: 15.9 nM
Beside the measured number, compound 4's estimate is 1.9-fold (0.28 log units) above it; low and high end bracket the measured number.
By their numbers in this assay, from the lowest: compounds 2, 3 and 4 (each within the scatter of the next, the first and the last beyond it); then compound 1.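

In this assay, within the data shown here, methyl in place of chloro on this aromatic carbon of the core gives a 3.2-fold lower number from compound 1 to compound 4 (0.50 log units; beyond the scatter), and this is the first pair that differs in one place only. The group at this position therefore matters for the number, even though the exchange swaps one heavy atom for one heavy atom and brings no ring, no hydrogen-bond donor or acceptor, and no net charge. Nothing shown here explains why the number falls, so the result stands as an observation for this one exchange on this one background, not as a general rule for the series.

From the compounds shown here alone, whether a fluoro, methoxy or nitrile group on the same aromatic carbon would give a lower or a higher number remains open, as does the number for plain hydrogen there with the rest of compound 4 unchanged. Also open, going by these compounds, is whether the same exchange would give a step of similar size when the core carries the sulfonyl aryl groups of compound 2 or compound 3.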